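Swapping the naphthalen-1-yl group for 2-fluorophenyl

The source may report more compounds than this note shows. Statements on the series, on what has been measured and on what is new or still open speak of the compounds shown alone.

Compound 1 `O=C(Nc1ccccc1F)Nc1cc2ncncc2cc1OCc1ccccc1F`: 3600 nM
Compound 2 `O=C(Nc1ccccc1F)Nc1cc2ncncc2cc1OCc1cccc(Cl)c1`: 4400 nM
Compound 3 `O=C(Nc1cc2ncncc2cc1OCc1cccc(F)c1)Nc1cccc2ccccc12`: 1400 nM
Compound 4 `O=C(Nc1ccccc1F)Nc1cc2ncncc2cc1OCc1cccc(F)c1`: not yet measured

In a functional assay on GBM2 cells (Homo sapiens) for antiproliferative activity, read by WST assay, with a stated time of 72 h (on this read-out lower numbers stand for stronger inhibition and higher numbers for weaker inhibition), compound 3 gives the lowest of the three numbers, 1400 nM, and its gaps to the other two lie beyond the scatter. The next structure replaces one group: 2-fluorophenyl in place of naphthalen-1-yl on an amide-type nitrogen. Going by the values given here, no measured step isolates this swap. However, compound 1 and compound 2 both carry 2-fluorophenyl on the amide-type nitrogen, and the step between them, a 1.2-fold higher number from compound 1 to compound 2 (0.09 log units; within the scatter), is small. A number close to theirs therefore seems likely. The expected change is a 2.7-fold higher number from compound 3 to compound 4 (0.43 log units; beyond the scatter), meaning weaker inhibition. For compound 4 the estimate is 3800 nM, with an expected range of 2000 nM to 7000 nM.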

Compound 4, half-maximal inhibitory concentration: 6400 nM
The estimate for compound 4 lay 1.7-fold (0.23 log units) below the measured number; the measured number falls inside the stated range.
By their numbers in this assay, from the lowest: compound 3; then compounds 1, 2 and 4 (each within the scatter of the next).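

In this assay the step of a 4.6-fold higher number from compound 3 to compound 4 (0.66 log units; beyond the scatter) isolates the change on the amide-type nitrogen, showing that naphthalen-1-yl gives stronger inhibition than 2-fluorophenyl when the rest of the molecule is held constant. By contrast, the steps of a 1.5-fold higher number from compound 2 to compound 4 (0.16 log units; within the scatter) and a 1.8-fold higher number from compound 1 to compound 4 (0.25 log units; within the scatter) show that the three benzyl-type variations in these compounds cannot be told apart. Nothing measured here accounts for the difference between the naphthalen-1-yl and 2-fluorophenyl groups.

From the compounds shown here alone, whether both aromatic rings of naphthalen-1-yl are needed remains open. Unsubstituted phenyl, naphthalen-2-yl or cyclohexyl on that nitrogen could help settle this.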